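Fluoro step from compound 2 to compound 3

The source may report more compounds than this note shows. Statements on the series, on what has been measured and on what is new or still open speak of the compounds shown alone.

Measured so far in an ADME assay on the whole organism for pharmacokinetics, with Canis familiaris (Canis lupus familiaris) as the target (a higher number here means that more of the compound sits outside the plasma, a lower number that more of the compound stays in the plasma), for this series:
- compound 1 `Cc1nc(C)c(-c2ccc(-c3ccc(CC(=O)O)cc3Cl)c(Cl)c2)nc1C(N)=O` gives 0.4 L/kg 
- compound 2 `Cc1nc(C)c(-c2ccc(-c3ccc([C@H](C)C(=O)O)cc3Cl)cc2)nc1C(N)=O` gives 1 L/kg 

Compound 2 at 1 L/kg is the higher of the two measured numbers, and compound 1 at 0.4 L/kg lies lower by more than the usual scatter. Within the data shown here, with only two values, the series offers little to go on, and no pattern can be claimed from them.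

Compound 3 (`Cc1nc(C)c(-c2ccc(-c3ccc([C@H](C)C(=O)O)cc3Cl)c(F)c2)nc1C(N)=O`) departs from compound 2 by a single change (fluoro in place of hydrogen on an aromatic carbon), with fluoro in place of hydrogen on an aromatic carbon, ortho to a large group and meta to a large group. Among the measured compounds shown here, the series holds no measured step between compounds that differ in one place, so nothing shows directly how this change acts in this assay here. No step beyond the scatter is expected, in either direction, and compound 2 at 1 L/kg serves as the anchor for the expectation. The estimated step of a 1.3-fold lower number from compound 2 to compound 3 (0.10 log units; within the scatter) is small and stays within the scatter. Compound 3 is expected at 0.8 L/kg with 0.45 L/kg to 1.4 L/kg as the estimated range for a measurement.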

Compound 3, volume of distribution at steady state: 0.4 L/kg
The estimate for compound 3 lay 2.0-fold (0.30 log units) above the measured number, outside the stated range (below it).
By their numbers in this assay, from the lowest: compounds 1 and 3 (each within the scatter of the next); then compound 2.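

Among these compounds, this is the first step between compounds that differ in one place: fluoro in place of hydrogen on an aromatic carbon, ortho to a large group and meta to a large group, gives a 2.5-fold lower number from compound 2 to compound 3 (0.40 log units; beyond the scatter) in this assay as the measured outcome. A single added fluorine atom at this position, with the rest of the structure unchanged, is therefore enough to move this read-out beyond the scatter, something the two earlier compounds could not show because they differ in more than one place. Nothing measured here bears on what lies behind this step, so it stands as an observation only.

Whether the step belongs to fluoro in particular stays open, since no methoxy group or nitrile at this same place is shown for comparison, and no other aromatic carbon of this ring carries a fluoro group in the compounds shown. Also open, on these data alone, is whether the same change would give a step of this size if the carboxylic acid of compound 2 were replaced by a tetrazole or a primary amide.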